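The source may hold more compounds than are shown below. What is called first, only, known or untested is meant among the compounds shown, and "the series" means these compounds.

Measured so far:
compound 1, `C=Cc1ccnc(C#Cc2ccc3ncn(-c4ccnc(N)n4)c3c2)n1`, 1580 nM;
compound 2, `C=Cc1nccc(C#Cc2ccc3ncn(-c4ccnc(N)n4)c3c2)n1`, 39800 nM.

In an assay on Sf9 cells for inhibition of mitogen-activated protein kinase kinase kinase 14 variant S549D (Homo sapiens), with a stated time of 30 min, in the presence of a further agent that is not named here (a higher number here means a weaker inhibitor, a lower number a stronger inhibitor), compound 2 gives the highest of the two numbers; its nearest neighbour is compound 1, and the step of a 25-fold higher number from compound 1 to compound 2 (1.40 log units; beyond the scatter) lies beyond the scatter. Compound 3, `C#Cc1cc(C#Cc2ccc3ncn(-c4ccnc(N)n4)c3c2)ncn1`, is not yet measured. It differs from compound 2 by a group of 8 heavy atoms (6 carbon, 2 nitrogen; one six-membered aromatic ring with 2 hetero atoms) in place of a group of 8 heavy atoms (6 carbon, 2 nitrogen; one six-membered aromatic ring with 2 hetero atoms), on a triple-bonded carbon; the group that leaves carries one double bond outside aromatic rings, the group that enters carries one triple bond outside aromatic rings. For the measured compounds named here, no measured step of the same kind exists. Going by the values given here, the only step at this position, a 25-fold higher number from compound 1 to compound 2 (1.40 log units; beyond the scatter), shows that swapping one such ring for another can move the number a great deal in either direction, so the direction for compound 3 is open. The estimate for compound 3 in this assay is 10000 nM, range 2000 nM to 50000 nM, which means an expected step of a 4.0-fold lower number from compound 2 to compound 3 (0.60 log units; beyond the scatter).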

Compound 3, half-maximal inhibitory concentration: 50100 nM
For compound 3 the middle estimate is 5.0-fold (0.70 log units) below the measured one, and the stated range ends below it.
By their numbers in this assay, from the lowest: compound 1; then compounds 2 and 3 (each within the scatter of the next).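

In this assay, replacing the ring group with one double bond outside the ring by the ring group with one triple bond gives a 1.3-fold higher number from compound 2 to compound 3 (0.10 log units; within the scatter), so compound 2 and compound 3 cannot be separated at this position. Against compound 1, the same ring-for-ring exchange on the triple-bonded carbon gives a 32-fold higher number from compound 1 to compound 3 (1.50 log units; beyond the scatter), so a second large step now separates compound 1 from the others, and compound 1 alone holds the low number. Nothing measured bears on why these ring groups give such numbers.

Open, on these data alone, is whether the ring group of compound 1 keeps its number when an amine or a methyl group stands in place of its double-bonded group. Also open, as far as these compounds go, is whether a triple-bonded group on that same ring group would give a number like that of compound 1 or like that of compound 3.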